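The source may hold more compounds than are shown below. What is called first, only, known or untested is meant among the compounds shown, and "the series" means these compounds.

Compound 1 `COc1ccc(/C=C2\S/C(=N\c3ccc(C(C)(C)C)cc3)N(C)C2=O)cc1` gives 46700 nM in an ADME assay on TERT-RPE1 cells (Homo sapiens) for cytotoxicity, read by MTT assay, with a stated time of 72 h; on this read-out lower numbers stand for stronger inhibition and higher numbers for weaker inhibition.
Compound 2 `COc1ccc(/C=C2/CN(C)/C(=N/c3ccc(C(F)(F)F)cc3)S2)cc1` gives 72000 nM in this assay.
Compound 3 `C=C1CN(C)/C(=N/c2ccccc2)S1` gives > 100000 nM in this assay, which is a limit of the assay rather than a number.

Among the numbers shown, compound 1 stands alongside compound 2, the two values lying within the usual scatter of each other. Compound 3 sits at the limit (the limit of > 100000 nM in this assay, at which 1 of the 3 values shown sits).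

Compound 4 `COc1ccc(/C=C2\S/C(=N\c3ccc(C)cc3)N(C)C2=O)cc1` differs from compound 1 only in one place: methyl in place of tert-butyl on an aromatic carbon. Among the compounds with values here, no measured pair shows what this kind of change does in this assay, so the size of the step is uncertain; a shift within the scatter, perhaps toward a somewhat higher number, seems the most likely outcome. For compound 4 the estimate in this assay is 70000 nM, with a range of 30000 nM to 160000 nM. This means an expected step of a 1.5-fold higher number from compound 1 to compound 4 (0.18 log units; within the scatter).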

Compound 4, half-maximal inhibitory concentration: > 100000 nM
Compound 4: no number, only a limit; the forecaster's own chance of this, stated with the estimate: 35%; middle value at least 1.4-fold (0.15 log units) away from the limit.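

In this assay, within the data shown here, methyl in place of tert-butyl on the aromatic carbon gives an at least 2.1-fold higher number from compound 1 to compound 4 (0.33 log units; beyond the scatter), the first measured step at this position, and it lies beyond the scatter. This position therefore responds to a change of group in this read-out. How large the step really is stays unknown, because compound 4 gives a limit of the assay and not a number: the limit of > 100000 nM in this assay, at which 2 of the 4 values shown sit.

An amine or a carboxylic acid at this position could give a number on either side of compound 1, and the compounds shown do not tell which. Going by these compounds, whether a longer chain would lower the number also stays open.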